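Adding a Second Chloro to a Chlorinated Purine Core

A few compounds are considered here, and "the series" means these few. Any claim that something is new, unique, unknown or untested is made for them only; others in the source may bear on it.

Measured compounds:
compound 1 `ClCc1ccc(Cn2cnc3c(Cl)ncnc32)cc1` — 97700 nM
compound 2 `ClCc1cccc(Cn2cnc3ncnc(Cl)c32)c1` — 18600 nM
compound 3 `ClCc1cccc(Cn2cnc3c(Cl)ncnc32)c1` — 67600 nM

In a functional assay on UACC-257 cells (Homo sapiens) for cytotoxicity, read by sulforhodamine B assay, with a stated time of 48 h (a higher number here means that more compound is tolerated, a lower number that less compound is tolerated), compound 3 gives 67600 nM, the second highest of the three numbers. Its nearest neighbour is compound 1, which in this assay gives 97700 nM; the two numbers lie within the scatter of each other, so no order between compound 3 and compound 1 can be read from them. Compound 2, with 18600 nM in this assay, stands furthest away, and the gap from compound 3 to compound 2 is beyond the scatter, so less of compound 2 is tolerated than of compound 3.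

Compound 4 `ClCc1cccc(Cn2cnc3c(Cl)nc(Cl)nc32)c1` has not yet been tested. It differs from compound 3 in one place: chloro in place of hydrogen on an aromatic carbon. Among the measured compounds shown here, no pair of measured compounds differs in just this way, so there is no measured step to lean on. The author expects the step from compound 3 to compound 4 in this assay to be small, a 1.5-fold lower number from compound 3 to compound 4 (0.18 log units; within the scatter), with a lower number somewhat more likely than a higher one but not clearly beyond the scatter. On that basis compound 4 is estimated at 45000 nM in this assay, with a range from 15000 nM to 140000 nM.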

Compound 4, concentration lethal to 50% of the cells: 6450 nM
The estimate for compound 4 lay 7.0-fold (0.84 log units) above the measured number, and the stated range ends above it.
By their numbers in this assay, from the lowest: compound 4; then compound 2; then compounds 3 and 1 (each within the scatter of the next).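

In this assay the entry of a single chloro on the aromatic carbon between two ring nitrogen atoms gives a 10-fold lower number from compound 3 to compound 4 (1.02 log units; beyond the scatter) and so marks the largest change in this small set that can be traced to one place. Compounds 1, 2 and 3 all carry hydrogen on this carbon, so they could not show whether substitution here matters; compound 4 shows that it does, and that one heavy atom, with no ring, no net charge and no hydrogen-bond donors or acceptors, is enough to make less of the compound tolerated. Nothing among the data shown accounts for the size of this step, so its cause stays unknown.

The compounds shown leave open whether this step belongs to chloro itself or to substitution on this carbon in general, since an amine, a methoxy group or a fluoro in the same place would be needed to tell these apart. They also leave open whether the same change would carry over to compound 1 or compound 2, and whether it depends on the chloromethyl group, which a plain methyl in its place would test.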